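A carbamoyl group on the shared core, still unmeasured

The compounds below may be only part of what the source reports. "The series", "measured", "known", "first", "only" and "open" are said of these compounds alone.

Measured so far in a toxicity assay on CCRF-CEM cells (Homo sapiens) for cytotoxicity; on this read-out higher numbers stand for lower toxicity in this test and lower numbers for higher toxicity in this test:
- Compound 1 `Nc1cccc2c1nc(-c1c(F)cccc1F)n2Cc1c(F)cccc1F` gives 26.3 uM
- Compound 2 `CC(=O)Nc1cccc2c1nc(-c1c(F)cccc1F)n2Cc1c(F)cccc1F` gives 39.3 uM
- Compound 3 `N=C(NO)c1cccc2c1nc(-c1c(F)cccc1F)n2Cc1c(F)cccc1F` gives 23.1 uM

Compound 3 does not stand apart from the other two compounds. Both steps that reach it, a 1.1-fold lower number from compound 1 to compound 3 (0.06 log units; within the scatter) and a 1.7-fold lower number from compound 2 to compound 3 (0.23 log units; within the scatter), lie within the scatter. The remaining step, a 1.5-fold higher number from compound 1 to compound 2 (0.17 log units; within the scatter), does too.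

The next change leads to compound 4 `NC(=O)c1cccc2c1nc(-c1c(F)cccc1F)n2Cc1c(F)cccc1F` and falls on an aromatic carbon of a six-membered aromatic ring of carbon only, part of a fused or bridged system of two rings. Carbamoyl enters there, and the difference from compound 3 is a group of 3 heavy atoms (1 carbon, 1 nitrogen, 1 oxygen; no ring) in place of a group of 4 heavy atoms (1 carbon, 2 nitrogen, 1 oxygen; no ring), on an aromatic carbon.

Within the data shown here, no measured step puts carbamoyl in this place, so the evidence is indirect. The group on this carbon already differs among the three measured compounds, and none of those differences has moved this assay beyond the scatter. The closest comparison is a 1.7-fold lower number from compound 2 to compound 3 (0.23 log units; within the scatter), an exchange of one group of 4 heavy atoms for another at this carbon. On that basis, no change beyond the scatter is expected here, and the estimated step is a 1.3-fold higher number from compound 3 to compound 4 (0.10 log units; within the scatter). For compound 4 the estimated value is 29 uM with an expected range from 15 uM to 55 uM.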

Compound 4, half-maximal toxic concentration: > 100 uM
Compound 4: only a limit was reported; the forecaster's own chance of this, stated with the estimate: 10%; middle value at least 3.4-fold (0.53 log units) from the limit.
By their numbers in this assay, from the lowest: compounds 3, 1 and 2 (each within the scatter of the next). At a limit, above all of these: compound 4.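

Compound 4 stands at a limit of the assay and not at a number in this assay: the limit of > 100 uM in this assay, at which 1 of the 4 values shown sits. Even so, the group on this aromatic carbon now moves the read-out beyond the scatter for the first time, with an at least 4.3-fold higher number from compound 3 to compound 4 (0.63 log units; beyond the scatter) and an at least 2.5-fold higher number from compound 2 to compound 4 (0.40 log units; beyond the scatter) and also an at least 3.8-fold higher number from compound 1 to compound 4 (0.58 log units; beyond the scatter). Among the compounds shown, the exchanges between amino, acetamido and the group of compound 3 left the numbers within the scatter of one another, whereas carbamoyl alone separates from all three, on the side of lower toxicity in this test.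

The compounds shown leave open how large the true difference is, since each of these steps rests on a limit, and they give no reason for the separation. They also leave open whether the effect belongs to carbamoyl alone or would extend to a carboxylic acid, a methyl ester or a nitrile on this carbon, and whether carbamoyl would behave the same way on another carbon of this ring.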